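Swapping Cyclohexyl for Methyl on a Shared Core

The source may report more compounds than this note shows. Statements on the series, on what has been measured and on what is new or still open speak of the compounds shown alone.

In an ADME assay on J774 cells (Mus musculus) for cytotoxicity (a lower number here means that less compound is needed, a higher number that more compound is needed for the effect), compound 3 (`COc1cc2[nH]c(C)c(C3CCCCC3)c(=O)c2cc1Cl`) gives > 32700 nM as its result, which is a limit and not a number. Compound 2 (`CCCCCCCCCc1c(C)[nH]c2cc(OC)c(Cl)cc2c1=O`) gives > 28700 nM as its result, which is also a limit. Of the measured compounds, only compound 1 (`CCc1c(C)[nH]c2cc(OC)c(Cl)cc2c1=O`) has a true number, at 19000 nM on the same scale.

Compound 4 (`COc1cc2[nH]c(C)c(C)c(=O)c2cc1Cl`) has not yet been measured. It differs from compound 3 by methyl in place of cyclohexyl on an aromatic carbon.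

Among the compounds with values here, two measured steps bear on this change. The closer one is an at least 1.7-fold higher number from compound 1 to compound 3 (0.23 log units; that floor lies within the scatter) for cyclohexyl in place of ethyl at that same carbon. The other is an at least 1.5-fold higher number from compound 1 to compound 2 (0.17 log units; that floor lies within the scatter) for heptyl in place of hydrogen on a saturated chain carbon. As far as these compounds go, both are only floors, so their true sizes are unknown. Methyl is a small group like the ethyl of compound 1, so the 19000 nM of compound 1 is the best guide available.

The expected change is an at least 1.6-fold lower number from compound 3 to compound 4 (0.21 log units; that floor lies within the scatter) in this assay as a modest move to a lower number. The estimated value for compound 4 is 20000 nM (expected range 10000 nM to 38000 nM).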

Compound 4, half-maximal effective concentration: 12200 nM
Compound 4: the middle estimate sits 1.6-fold (0.21 log units) above what was measured; measured number inside the range.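

Putting methyl in place of cyclohexyl on this aromatic carbon gives an at least 2.6-fold lower number from compound 3 to compound 4 (0.42 log units; beyond the scatter), so in this assay a change at this position now shows up beyond the scatter, which neither of the earlier floors did. The long chain behaves in the same direction, with hydrogen in place of octyl on the chain carbon bound to the aromatic carbon giving an at least 2.3-fold lower number from compound 2 to compound 4 (0.37 log units; beyond the scatter), so among these compounds the small methyl stands apart from both large groups, although compound 1, with its ethyl, is not separated beyond the scatter from either of them. Between the two small groups no difference can be claimed, as the step is a 1.6-fold lower number from compound 1 to compound 4 (0.19 log units; within the scatter), which means that one extra carbon on a small chain changes little here.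

The true distance between methyl and cyclohexyl stays open, because compound 3 has only a limit and not a number: the limit of > 32700 nM in this assay, at which 1 of the 4 values shown sits. Also open is how this position would respond to a group of another kind, such as an amine or a carboxylic acid, since every group shown here is made of carbon only.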